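This account rests on a few compounds, and the source may have more. Where it says the series, first, only, none or still open, it means among the compounds named here.

Compound 3 `O=C(O)c1ccc2c(CN3CCC[C@H](O[C@H](CO)c4cc(Cl)cc(Cl)c4)[C@@H]3c3ccccc3)c[nH]c2c1` gives the highest number of the three measured compounds in an assay on isolated protein for activation of cGMP-dependent protein kinase 1 (Homo sapiens), read by ADP-Glo, with stated times of 120 min and 40 min (a lower number here means that less compound is needed, a higher number that more compound is needed for the effect), namely 22000 nM; compound 1 `O=C(O)c1ccc(CN2CCC[C@H](O[C@H](CO)c3cc(Cl)cc(Cl)c3)[C@@H]2c2ccccc2)cc1` gives 11000 nM and compound 2 `OC[C@@H](O[C@H]1CCCN(Cc2cccc3nonc23)[C@H]1c1ccccc1)c1cc(Cl)cc(Cl)c1` gives 8000 nM. The step of a 2.0-fold higher number from compound 1 to compound 3 (0.30 log units; within the scatter) lies within the scatter, while a 2.8-fold higher number from compound 2 to compound 3 (0.44 log units; beyond the scatter) is modest. Compound 4 `CN1CCC[C@H](O[C@H](CO)c2cc(Cl)cc(Cl)c2)[C@@H]1c1ccccc1` differs from compound 3 by hydrogen in place of 6-carboxy-1H-indol-3-yl on a saturated chain carbon bound to an amine nitrogen in a ring. Within the data shown here, none of the measured steps removes this group altogether; each only exchanges one aromatic group for another, with a 1.4-fold lower number from compound 1 to compound 2 (0.14 log units; within the scatter) the smallest of them. Since those exchanges moved this assay little, the group seems to matter little, and compound 4 is expected near compound 3, estimated at 20000 nM (range 6000 nM to 60000 nM), the expected step being a 1.1-fold lower number from compound 3 to compound 4 (0.04 log units; within the scatter).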

Compound 4, half-maximal effective concentration: 42000 nM
For compound 4 the middle estimate is 2.1-fold (0.32 log units) below the measured one, and the stated range covers the measured number.
By their numbers in this assay, from the lowest: compounds 2, 1, 3 and 4 (each within the scatter of the next, the first and the last beyond it).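

Removing the aromatic group altogether in this assay gives a 5.3-fold higher number from compound 2 to compound 4 (0.72 log units; beyond the scatter) and a 3.8-fold higher number from compound 1 to compound 4 (0.58 log units; beyond the scatter) and so shows, as the exchanges of one aromatic group for another could not, that a group at this position counts for something, though only modestly. The 6-carboxy-1H-indol-3-yl group goes against this, since a 1.9-fold higher number from compound 3 to compound 4 (0.28 log units; within the scatter) stays inside the usual spread of repeated measurements. No data are available that explain these differences. As far as these compounds go, what an unsubstituted phenyl group or a longer chain ending in a carboxylic acid would give on this carbon remains open.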